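The compounds below may be only part of what the source reports. "The series", "measured", "known", "first", "only" and "open" are said of these compounds alone.

Compound 2 `Cc1cccc2sc(NC(=O)CCN3CCN(CCN(C(C)C)C(C)C)CC3)nc12` holds the lower of the two numbers seen so far in an assay on membranes from liver for displacement of a labelled ligand from Sigma intracellular receptor 2 (Rattus norvegicus), read by scintillation counting, with a stated time of 120 min (a lower number here means a stronger inhibitor, a higher number a weaker inhibitor), where compound 2 gives 121 nM while compound 1 `Cc1cccc2sc(NC(=O)CCN3CCN(C(C)C)CC3)nc12` gives 1800 nM. Compound 3 `Cc1ccccc1N1CCN(CCC(=O)Nc2nc3c(C)cccc3s2)CC1` differs from compound 2 by 2-methylphenyl in place of 2-(diisopropylamino)ethyl on an amine nitrogen in a ring. Going by the values given here, only one measured step bears on this position, a 15-fold lower number from compound 1 to compound 2 (1.17 log units; beyond the scatter), and it shows that the group on this ring nitrogen moves the number a great deal. With an entering group unlike either seen before, compound 3 is expected to lose some ground, a 2.9-fold higher number from compound 2 to compound 3 (0.46 log units; beyond the scatter). Compound 3 is therefore estimated at 350 nM, with a range from 70 nM to 1800 nM.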

Compound 3, inhibition constant: > 1000 nM
Compound 3: no number, only a limit; the forecaster's own chance of this, stated with the estimate: 5%; middle value at least 2.8-fold (0.45 log units) away from the limit.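

The reading for compound 3 in this assay is a limit and not a number: the limit of > 1000 nM in this assay, at which 1 of the 3 values shown sits. Putting 2-methylphenyl in place of 2-(diisopropylamino)ethyl on this ring nitrogen gives an at least 8.2-fold higher number from compound 2 to compound 3 (0.91 log units; beyond the scatter), so this aromatic group does not keep the standing of compound 2, and the position does not accept any large group equally. The step between compound 1 and compound 3 cannot be read.

From the compounds shown here alone, it remains open whether the amine nitrogen of the chain matters, and how a benzyl group, an unsubstituted phenyl or a 2-(dimethylamino)ethyl chain would read here.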